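The source may hold more compounds than are shown below. What is called first, only, known or untested is meant among the compounds shown, and "the series" means these compounds.

In a functional assay on DLD-1 cells (Homo sapiens) for cytotoxicity, read by MTT assay (on this read-out lower numbers stand for stronger inhibition and higher numbers for weaker inhibition), compound 1 (`COc1cc(/C=C/C(=O)C(=Cc2ccc(O)cc2)C(=O)/C=C/c2ccc(O)c(OC)c2)ccc1O`) gives 4080 nM, compound 2 (`COc1cc(/C=C/C(=O)C(=Cc2ccccc2)C(=O)/C=C/c2ccc(O)c(OC)c2)ccc1O`) gives 5450 nM and compound 3 (`CCOc1cc(/C=C/C(=O)C(=Cc2ccc(O)c(OC)c2)C(=O)/C=C/c2ccc(O)c(OCC)c2)ccc1O`) gives 9630 nM. Compound 3 thus lies within the scatter of compound 2 and beyond the scatter above compound 1. Compound 4 (`CCOc1cc(/C=C/C(=O)C(=Cc2ccc(OCC)c(OCC)c2)C(=O)/C=C/c2ccc(O)c(OCC)c2)ccc1O`) differs from compound 3 in one place: 3,4-diethoxyphenyl in place of 4-hydroxy-3-methoxyphenyl on a double-bonded chain carbon bound to a double-bonded chain carbon. Among the measured compounds shown here, the only measured step that bears on this change is a 1.3-fold higher number from compound 1 to compound 2 (0.13 log units; within the scatter), where hydrogen replaces hydroxy on an aromatic carbon, and it stays within the scatter. For the measured compounds named here, no measured step shows what 3,4-diethoxyphenyl itself does, so the estimate is uncertain. The expected step, none beyond the scatter, is a 1.0-fold higher number from compound 3 to compound 4 (0.02 log units; within the scatter). For compound 4 the estimated value is 10000 nM, with an expected range of 4500 nM to 22000 nM.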

Compound 4, half-maximal inhibitory concentration: 3450 nM
Estimate against measurement, compound 4: 2.9-fold (0.46 log units) above; the measured number lies below the stated range.
By their numbers in this assay, from the lowest: compounds 4, 1, 2 and 3 (each within the scatter of the next, the first and the last beyond it).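

In this assay, 3,4-diethoxyphenyl in place of 4-hydroxy-3-methoxyphenyl gives a 2.8-fold lower number from compound 3 to compound 4 (0.45 log units; beyond the scatter), so a change at this position moves the number beyond the scatter, which the earlier step of a 1.3-fold higher number from compound 1 to compound 2 (0.13 log units; within the scatter) did not do. The entering group counts no hydrogen-bond donor where the leaving group counts one. Nothing measured here gives a reason for this step. Going by these compounds, it remains open whether ethoxy for hydroxy or ethoxy for methoxy carries the step, and how a longer chain such as butoxy or an amine would fare here.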